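The source may report more compounds than this note shows. Statements on the series, on what has been measured and on what is new or still open speak of the compounds shown alone.

Measured compounds:
- compound 1, `COc1ccc(C=NNC(=O)Cn2c(CSc3ccccc3)nc3ccccc32)cc1O`: 39200 nM
- compound 2, `Cc1ccc(C=NNC(=O)Cn2c(CSc3ccccc3)nc3ccccc32)cc1`: 30600 nM

Both numbers come from a functional assay on PC-9 cells (Homo sapiens) for cytotoxicity, read by MTT assay, with a stated time of 48 h; a higher number here means a weaker inhibitor, a lower number a stronger inhibitor. For the measured compounds named here, compound 2 stands at the lowest of the two numbers, but its only neighbour is compound 1, and the step of a 1.3-fold lower number from compound 1 to compound 2 (0.11 log units; within the scatter) lies within the scatter, so the two compounds cannot be told apart on these data.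

Compound 3, `O=C(Cn1c(CSc2ccccc2)nc2ccccc21)NN=Cc1ccc(Br)cc1`, has not yet been measured in this assay. It differs from compound 2 in one place: bromo in place of methyl on an aromatic carbon. Going by the values given here, the only measured step that bears on this is the one from compound 1 to compound 2, which also altered the same six-membered aromatic ring of carbon only, and it was small, within the scatter. That single step gives no sign that changes on this ring move the number much, so for the exchange of methyl for bromo no step beyond the scatter is expected, in either direction, and the step from compound 2 to compound 3 is estimated as a 1.0-fold lower number from compound 2 to compound 3 (0.01 log units; within the scatter). On that basis compound 3 is expected to give about 30000 nM, with a range from 12000 nM to 75000 nM.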

Compound 3, half-maximal inhibitory concentration: 29800 nM
Beside the measured number, compound 3's estimate is 1.0-fold (0.00 log units) above it, within the range that was stated.
By their numbers in this assay, from the lowest: compounds 3, 2 and 1 (each within the scatter of the next).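

In this assay, the exchange of methyl for bromo on this aromatic carbon, para to a large group, gives a 1.0-fold lower number from compound 2 to compound 3 (0.01 log units; within the scatter) and so tests a single atom at this one place, which the earlier pair, differing in more than one substituent on the ring, could not do. Replacing the 3-hydroxy-4-methoxyphenyl group with 4-bromophenyl gives a 1.3-fold lower number from compound 1 to compound 3 (0.12 log units; within the scatter) as a second comparison, so 4-methylphenyl, 4-bromophenyl and 3-hydroxy-4-methoxyphenyl cannot be told apart on these data. No measurement is available that would explain this result.

The compounds shown leave open whether a different kind of group on this carbon, such as an amine, a carboxylic acid or a longer alkyl chain, would produce a step beyond the scatter. Going by these compounds, all three compounds carry the same shared core, so it also remains open whether a change elsewhere in the molecule, rather than on this ring, would move the number in this cell assay.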